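The compounds below may be only part of what the source reports. "The series", "measured", "known", "first", "only" and "open" are said of these compounds alone.

Compound 1 `C[C@@H](O)[C@H]1C(=O)N2C(C(=O)OCOC(=O)OC3Cc4ccccc4C3)=C(S[C@@H]3CN[C@H](C(=O)N(C)C)C3)[C@H](C)[C@H]12` shares its core with compound 2 `CC(C)OC(=O)OC(C)OC(=O)C1=C(S[C@@H]2CN[C@H](C(=O)N(C)C)C2)[C@H](C)[C@@H]2[C@@H]([C@@H](C)O)C(=O)N12` and compound 3 `C[C@@H](O)[C@H]1C(=O)N2C(C(=O)OCOC(=O)O[C@H]3CCCCc4ccccc43)=C(S[C@@H]3CN[C@H](C(=O)N(C)C)C3)[C@H](C)[C@H]12`, the three differing only in the group on an oxygen next to a carbonyl group. In a physicochemical assay for metabolic stability, read by HPLC, in simulated gastric fluid, at pH 1.2, tested at 100 uM (a lower number here means that the compound disappears faster, a higher number that the compound lasts longer), compound 1 gives 0.217 h, the highest of the two single numbers in this set; compound 3 gives 0.155 h, and compound 2 is recorded with 0.163 h; 0.147 h (2 entries), so its repeats are noted as the several entries of compound 2 in this assay, 0.163 h; 0.147 h (2 entries) rather than as one number. Among the measured compounds shown here, the move a 1.4-fold lower number from compound 1 to compound 3 (0.15 log units; within the scatter) is the only step among the measured compounds that bears on the new one.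

Compound 4 `C[C@@H](O)[C@H]1C(=O)N2C(C(=O)OCOC(=O)OC3CCc4ccccc4C3)=C(S[C@@H]3CN[C@H](C(=O)N(C)C)C3)[C@H](C)[C@H]12` is reached from compound 1 by the change (1,2,3,4-tetrahydronaphthalen-2-yl in place of 2,3-dihydro-1H-inden-2-yl on an oxygen next to a carbonyl group). This resembles the change from compound 1 to compound 3, which stayed within the scatter, so no step beyond the scatter in this assay is expected, at most a slight drift downward. Compound 4 is therefore expected at 0.18 h, between 0.1 h and 0.33 h, meaning a step of a 1.2-fold lower number from compound 1 to compound 4 (0.08 log units; within the scatter).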

Compound 4, half-life: 0.233 h
The estimate for compound 4 lay 1.3-fold (0.11 log units) below the measured number, within the range that was stated.
By their numbers in this assay, from the lowest: compounds 3, 1 and 4 (each within the scatter of the next).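

In this assay, the change to 1,2,3,4-tetrahydronaphthalen-2-yl gives a 1.1-fold higher number from compound 1 to compound 4 (0.03 log units; within the scatter), and the comparison with the group of compound 3 gives a 1.5-fold higher number from compound 3 to compound 4 (0.18 log units; within the scatter). All three pairs among compounds 1, 3 and 4 now lie within the scatter, so at this place, on an oxygen next to a carbonyl group, carbon-only groups with a five-, six- or seven-membered non-aromatic ring are not told apart by this read-out. Repeat readings in this set lie close together, which gives a direct view of how near such numbers can fall: the several entries of compound 2 in this assay, 0.163 h; 0.147 h (2 entries)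

The compounds shown leave open whether an amine or a carboxylic acid on this ring would move the half-life beyond the scatter. They also leave open whether a longer open alkyl chain in its place would do so.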